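Cytotoxicity notes on a pyridazinone-free view of the series

The compounds below may be only part of what the source reports. "The series", "measured", "known", "first", "only" and "open" are said of these compounds alone.

Two members of the series have been run in an ADME assay on Huh-7 cells (Homo sapiens) for cytotoxicity, with a stated time of 72 h (a higher number here means that more compound is tolerated, a lower number that less compound is tolerated), and both came back at the edge of the assay. Compound 1 `CC(C)=Cc1nn(CCC(C)C)c(=O)c(C2=NS(=O)(=O)c3cc(NS(C)(=O)=O)ccc3N2)c1O` gave > 1000 nM in this assay, which is a limit rather than a number. Compound 2 `COCCn1nc(-c2cccs2)c(O)c(C2=NS(=O)(=O)c3cc(NS(C)(=O)=O)ccc3N2)c1=O` likewise gave > 1000 nM in this assay, again a limit and not a measured value. So compound 2 stands where every value so far stands, at the limit of > 1000 nM in this assay, at which 2 of the 2 values shown sit, and nothing measured separates it from compound 1.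

Compound 3 `CS(=O)(=O)Nc1ccc2c(c1)S(=O)(=O)N=C(c1c(O)c(-c3cccs3)nn(Cc3ccc(F)cc3)c1=O)N2` is the next analogue and has not yet been tested in this assay. It differs from compound 2 as follows: 4-fluorophenyl in place of methoxymethyl on a saturated chain carbon bound to an aromatic nitrogen. Within the data shown here, no measured step between compounds exists here to gauge what such a change does in this assay, so the expectation rests only on where compound 2 sits.

With both measured compounds at the limit, the expected step from compound 2 to compound 3 is a step that the limit leaves unreadable from compound 2 to compound 3, that is, none beyond the scatter. Compound 3 is therefore estimated at 1500 nM in this assay, within a range of 500 nM to 5000 nM, and most likely reported again only as a limit.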

Compound 3, half-maximal cytotoxic concentration: > 1000 nM
Compound 3: only a limit was reported (the forecaster's own chance of this, stated with the estimate: 70%); the middle value lies beyond the limit too.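

In this assay compound 3 gave > 1000 nM as a limit and not a number. Compound 2 also stands at a limit, so no step can be read between compound 2 and compound 3. The compounds shown leave open how far any of them lies beyond the limit, and whether the change from 2-methoxyethyl to 4-fluorobenzyl alters the read-out at all.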